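The compounds below may be only part of what the source reports. "The series", "measured", "known", "first", "only" and "open" are said of these compounds alone.

Measured compounds:
compound 1 `CC(=O)NS(=O)(=O)c1ccc(N/C(S)=N\c2ccnc3cc(C(F)(F)F)ccc23)cc1` — 58600 nM
compound 2 `Cc1noc(NS(=O)(=O)c2ccc(N/C(S)=N\c3ccnc4cc(C(F)(F)F)ccc34)cc2)c1C` — 27900 nM

Going by the values given here, in a functional assay on MDA-MB-231 cells (Homo sapiens) for antiproliferative activity, read by sulforhodamine B assay, with a stated time of 48 h (on this read-out higher numbers stand for weaker inhibition and lower numbers for stronger inhibition), compound 2 gives the lowest of the two numbers, and its nearest neighbour is compound 1 at 58600 nM; the only step between them, a 2.1-fold lower number from compound 1 to compound 2 (0.32 log units; beyond the scatter), came from exchanging the acetyl on the sulfonamide nitrogen for the dimethyl-oxazolyl group. Compound 3 `O=S(=O)(Nc1ccccn1)c1ccc(N/C(S)=N\c2ccnc3cc(C(F)(F)F)ccc23)cc1` is not yet measured. It differs from compound 2 in one place: pyridin-2-yl in place of 3,4-dimethyl-1,2-oxazol-5-yl on a sulfonamide nitrogen. Among the compounds with values here, no measured pair exchanges one aromatic ring for another at this position, so the single step on record bears on it only loosely, showing that a change on this nitrogen can shift the number modestly. For compound 3 the expectation in this assay is therefore a value close to that of compound 2, with no step beyond the scatter, a 1.1-fold higher number from compound 2 to compound 3 (0.03 log units; within the scatter). The estimate for compound 3 is 30000 nM, ranging from 12000 nM to 75000 nM.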

Compound 3, half-maximal inhibitory concentration: 49300 nM
Estimate against measurement, compound 3: 1.6-fold (0.22 log units) below, and the stated range covers the measured number.
By their numbers in this assay, from the lowest: compounds 2, 3 and 1 (each within the scatter of the next, the first and the last beyond it).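

In this assay, going by these compounds alone, the only exchange of one aromatic ring for another on the sulfonamide nitrogen gives a 1.8-fold higher number from compound 2 to compound 3 (0.25 log units; within the scatter) so pyridin-2-yl and 3,4-dimethyl-1,2-oxazol-5-yl cannot be told apart at this place. The exchange of acetyl for pyridin-2-yl gives a 1.2-fold lower number from compound 1 to compound 3 (0.08 log units; within the scatter) and so also stays inside the scatter, which shows that the step seen with 3,4-dimethyl-1,2-oxazol-5-yl does not extend to every aromatic ring placed on this nitrogen. Nothing available explains these numbers. The compounds shown leave open whether an amine, a carboxylic acid or a longer alkyl chain on this nitrogen would shift the number by more than the scatter in this assay. They also leave open how a change elsewhere on the shared core would read.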